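Pyridine swap on the amide nitrogen of the shared core

The source may hold more compounds than are shown below. What is called first, only, known or untested is meant among the compounds shown, and "the series" means these compounds.

In an in vitro ADME assay on microsomes from liver (Homo sapiens) for pharmacokinetics, read by LC-MS, with a stated time of 10 min, tested at 1 uM (a lower number here means slower removal, a higher number faster removal of the compound), compound 1 (`COc1ccc(NC(=O)[C@H]2CN(C)C[C@@H]2c2ccc(/C=C/C(=O)Nc3ccccc3N)cc2)cc1`) gives 14 mL/min/kg and compound 2 (`CN1C[C@H](C(=O)Nc2ccc(Cl)c(Cl)c2)[C@@H](c2ccc(/C=C/C(=O)Nc3ccccc3N)cc2)C1`) gives 14 mL/min/kg as read-outs. Compound 3 (`Cc1ccc(NC(=O)[C@H]2CN(C)C[C@@H]2c2ccc(/C=C/C(=O)Nc3ccccc3N)cc2)cn1`) gives 8 mL/min/kg and stands within the scatter of both. Compound 4 (`CN1C[C@H](C(=O)Nc2ccccn2)[C@@H](c2ccc(/C=C/C(=O)Nc3ccccc3N)cc2)C1`) carries pyridin-2-yl in place of 6-methylpyridin-3-yl on an amide-type nitrogen. Three measured steps at this same place bear on the change: no change at the digits printed from compound 1 to compound 2 (within the scatter) and a 1.8-fold lower number from compound 1 to compound 3 (0.24 log units; within the scatter) and a 1.8-fold lower number from compound 2 to compound 3 (0.24 log units; within the scatter) all remain within the scatter. None of them involves pyridin-2-yl. No shift beyond the scatter is therefore expected in this assay in either direction. The expected step is a 1.3-fold higher number from compound 3 to compound 4 (0.10 log units; within the scatter) and stays within the scatter. For compound 4 the estimate is 10 mL/min/kg with an expected range (5 mL/min/kg to 20 mL/min/kg).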

Compound 4, clearance: 8 mL/min/kg
The estimate for compound 4 lay 1.3-fold (0.10 log units) above the measured number, and the stated range covers the measured number.
By their numbers in this assay, from the lowest: compounds 3, 4, 1 and 2 (each within the scatter of the next).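

In this assay pyridin-2-yl on the amide-type nitrogen gives no change at the digits printed from compound 3 to compound 4 (within the scatter) and a 1.8-fold lower number from compound 2 to compound 4 (0.24 log units; within the scatter) and a 1.8-fold lower number from compound 1 to compound 4 (0.24 log units; within the scatter) and all three steps stay within the scatter. The unsubstituted pyridin-2-yl therefore reads like 6-methylpyridin-3-yl here, and no change at this position among the four compounds moves the number beyond the scatter. Nothing available gives a reason for these readings.

Still open, going by these compounds, is whether a carboxylic acid or an aminomethyl group on the ring at this nitrogen would shift clearance beyond the scatter.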